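Cytotoxicity notes: amide substituent change on the shared core

The source may hold more compounds than are shown below. What is called first, only, known or untested is meant among the compounds shown, and "the series" means these compounds.

Measured so far:
compound 1 `Cc1nc(C(NC(=O)C(=O)Nc2ccc(Cl)cc2)C2CCCCN2)sc1CO` — > 22000 nM
compound 2 `Cc1nc(C(NC(=O)C(=O)Nc2ccc(Cl)cc2)C2CCCNC2)sc1CO` — 60200 nM

In an ADME assay on TZM-b1 cells (Homo sapiens) for cytotoxicity, read by XTT assay, with a stated time of 3 days (a lower number here means that less compound is tolerated, a higher number that more compound is tolerated), compound 1 reaches only a limit of the assay, > 22000 nM, and not a number. Compound 2 gives 60200 nM in the same assay. The step from compound 1 to compound 2, piperidin-3-yl in place of piperidin-2-yl on a saturated chain carbon bound to an amide-type nitrogen and an aromatic carbon, is a step that the limit leaves unreadable from compound 1 to compound 2 because of the limit of > 22000 nM in this assay, at which 1 of the 2 values shown sits, so its size cannot be read.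

Compound 3 `Cc1nc(C(NC(=O)C(=O)NC2CCCCCC2)C2CCCCN2)sc1CO` is not yet measured. It differs from compound 1 as follows: cycloheptyl in place of 4-chlorophenyl on an amide-type nitrogen. Going by the values given here, no measured step touches the amide-type nitrogen at which this change sits, so none of the two measured steps bears directly on it; the only readable fact is that both measured compounds are tolerated to high concentrations. On that basis compound 3 is expected to remain little toxic, with an expected step that the limit leaves unreadable from compound 1 to compound 3 from compound 1. The estimate for compound 3 is 40000 nM, within 15000 nM to 110000 nM, and a limit rather than a number is a real possibility.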

Compound 3, half-maximal cytotoxic concentration: > 90000 nM
Compound 3 gave a limit, no number; the forecaster's own chance of this, stated with the estimate: 55%; middle value at least 2.2-fold (0.35 log units) away from the limit.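

No step can be read between compound 1 and compound 3, because both give only a limit and not a number, the new one being: the limit of > 90000 nM in this assay, at which 1 of the 3 values shown sits.

The compounds shown leave open how far cycloheptyl in place of 4-chlorophenyl on an amide-type nitrogen shifts the read-out in this assay.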